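Compound 2 and its naphthalen-2-yl partner

A few compounds are considered here, and "the series" means these few. Any claim that something is new, unique, unknown or untested is made for them only; others in the source may bear on it.

Compound 1 `CCSc1nnc(-c2cc(OC)c(OC)c(OC)c2)n1-c1ccc(N(C)C)cc1`: > 60000 nM
Compound 2 `COc1cc(-c2nnc(SCC(=O)c3ccccc3)n2-c2ccc(N(C)C)cc2)cc(OC)c1OC`: 18900 nM

Among the compounds with values here, in a functional assay on HepG2 cells (Homo sapiens) for inhibition, read by MTT assay, with a stated time of 48 h (on this read-out higher numbers stand for weaker inhibition and lower numbers for stronger inhibition), compound 2 gives 18900 nM, the only actual number so far. Compound 1 reaches only a limit of the assay, > 60000 nM. Within the data shown here, the one measured step, an at least 3.1-fold lower number from compound 1 to compound 2 (0.50 log units; beyond the scatter), came with benzoyl in place of methyl on a saturated chain carbon bound to a sulfur, and it rests on that limit (the limit of > 60000 nM in this assay, at which 1 of the 2 values shown sits). Compound 3 `COc1cc(-c2nnc(SCC(=O)c3ccc4ccccc4c3)n2-c2ccc(N(C)C)cc2)cc(OC)c1OC` differs from compound 2 by one change: naphthalen-2-yl in place of phenyl on a carbonyl carbon. That earlier step bears on this change only indirectly, so a modest lowering in this assay is expected, the estimated step being a 2.1-fold lower number from compound 2 to compound 3 (0.32 log units; beyond the scatter). For compound 3 the estimated value is 9000 nM, with an expected range from 2500 nM to 30000 nM.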

Compound 3, half-maximal inhibitory concentration: > 60000 nM
Compound 3: a limit, no number; the forecaster's own chance of this, stated with the estimate: 10%; middle value at least 6.6-fold (0.82 log units) away from the limit.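

In this assay, naphthalen-2-yl in place of phenyl on a carbonyl carbon gave an at least 3.1-fold higher number from compound 2 to compound 3 (0.50 log units; beyond the scatter), so the second aromatic ring did not extend the gain seen with benzoyl but removed it. Of the groups shown on this carbonyl carbon, only phenyl gives a readable number. The step from compound 1 to compound 3 cannot be read: the limit of > 60000 nM in this assay, at which 2 of the 3 values shown sit.

As far as these compounds go, whether morpholine or cyclohexyl in place of phenyl on this carbonyl carbon would keep or lower the number of compound 2 remains open.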